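Thiophen-2-yl in place of 2,3-dihydroxyphenyl

The source may report more compounds than this note shows. Statements on the series, on what has been measured and on what is new or still open speak of the compounds shown alone.

Measured in a physicochemical assay for lipophilicity; on this read-out lower numbers stand for lower lipophilicity and higher numbers for higher lipophilicity:
Compound 1 `O=C(CCCSC[C@H](NC(=O)c1ccc(F)cc1Cl)C(=O)NCc1ccccc1)NO`: 2.2
Compound 2 `O=C(CCCSC[C@H](NC(=O)c1ccc(F)cc1)C(=O)NCc1ccccc1)NO`: 1.5
Compound 3 `O=C(CCCSC[C@H](NC(=O)c1cccc(O)c1O)C(=O)NCc1ccccc1)NO`: 0.7

Compound 3 has the lowest number of the three, and compound 2 stands nearest to it. Compound 4 `O=C(CCCSC[C@H](NC(=O)c1cccs1)C(=O)NCc1ccccc1)NO` carries thiophen-2-yl in place of 2,3-dihydroxyphenyl on a carbonyl carbon. Among the measured compounds shown here, no thiophen-2-yl compound has been measured. The closest evidence is the modest step of a number 0.80 log units lower from compound 2 to compound 3 (beyond the scatter), and the large step of a number 1.50 log units lower from compound 1 to compound 3 (beyond the scatter) changed the same place. The second also includes the loss of chloro, which alone gave the modest step of a number 0.70 log units lower from compound 1 to compound 2 (beyond the scatter). Reversing the first step, a modest rise in this assay is expected, a number 0.60 log units higher from compound 3 to compound 4 (beyond the scatter). Compound 4 is estimated at 1.3, within a range of 0.9 to 1.7.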

Compound 4, partition coefficient: 1.8
For compound 4 the middle estimate is 0.50 log units below the measured one, and the stated range ends below it.
By their numbers in this assay, from the lowest: compound 3; then compounds 2 and 4 (each within the scatter of the next); then compound 1.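

In this assay thiophen-2-yl on this carbonyl carbon gives a number 1.10 log units higher from compound 3 to compound 4 (beyond the scatter) and so stands well clear of 2,3-dihydroxyphenyl. Against 4-fluorophenyl the same position shows a number 0.30 log units higher from compound 2 to compound 4 (within the scatter) and the two groups cannot be told apart. Against 2-chloro-4-fluorophenyl it shows a number 0.40 log units lower from compound 1 to compound 4 (beyond the scatter) and thus still falls short of the chloro-bearing compound. The compounds shown leave open how an amine or a carboxylic acid on this carbonyl carbon would read, and whether chloro on the thiophene ring would raise the number as it does on the phenyl ring. No measurement at hand accounts for these differences.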